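Swapping carboxy for pyridin-3-yl on a shared core

The compounds below may be only part of what the source reports. "The series", "measured", "known", "first", "only" and "open" are said of these compounds alone.

Clearance tells how quickly liver enzymes remove a compound, and three compounds have so far gone through an in vitro ADME assay on microsomes from liver (Homo sapiens) for metabolic stability, tested at 0.2 uM (on this read-out lower numbers stand for slow clearance and higher numbers for fast clearance), with sparse results. Compound 2 `Cc1c(COc2cccc(OCC3CCOCC3)c2)[nH]c2ccc(C(=O)O)cc2c1=O` gives < 20 mL/min/kg in this assay as a limit of the assay and not as a number. Compound 1 `Cc1c(COc2ccnc(OCC3CCOCC3)c2)[nH]c2ccccc2c1=O` gives 95 mL/min/kg in this assay and carries no carboxy group. Compound 3 `CC(C)c1c(COc2cccc(OCC3CCOCC3)c2)[nH]c2ccccc2c1=O` has the entry "not determined" (no result reported) in this assay and so adds nothing to the comparison.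

Compound 4 `Cc1c(COc2cccc(OCC3CCOCC3)c2)[nH]c2ccc(-c3cccnc3)cc2c1=O` has not yet been measured. It differs from compound 2 in one place, and the change pyridin-3-yl in place of carboxy on an aromatic carbon puts pyridin-3-yl in place of carboxy on an aromatic carbon. Going by the values given here, no measured pair shows this swap. Among the compounds with values here, compound 1 at 95 mL/min/kg is the only number for a compound without the carboxy group, and it also differs from compound 4 elsewhere, so a rise in clearance beyond the usual scatter is expected, though only loosely. The estimated step is an at least 3.0-fold higher number from compound 2 to compound 4 (0.47 log units; beyond the scatter) and it stays rough. In this assay the expected value for compound 4 is 60 mL/min/kg within an estimated range of 25 mL/min/kg to 130 mL/min/kg on the same scale.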

Compound 4, clearance: 756 mL/min/kg
For compound 4 the middle estimate is 13-fold (1.10 log units) below the measured one; the measured number lies above the stated range.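

In this assay, going by these compounds alone, putting pyridin-3-yl in place of carboxy on this aromatic carbon gives an at least 37-fold higher number from compound 2 to compound 4 (1.57 log units; beyond the scatter), the first comparison here in which only one place on the molecule changes. Within the data shown here, until now, no pair could tie a change in clearance to this position alone, whereas this one shows that the group on this carbon of the shared core can by itself separate a slowly cleared compound from a very rapidly cleared one. As far as these compounds go, the step is a minimum and its full size remains unknown because compound 2 is recorded as a limit of the assay and not as a number: the limit of < 20 mL/min/kg in this assay, at which 1 of the 4 values shown sits.

The swap removes a carboxy group and brings in a six-membered aromatic ring with a ring nitrogen, and this single pair cannot tell whether losing the one or gaining the other drives the step. From the compounds shown here alone, a primary amide or a plain phenyl ring on the same aromatic carbon would help to separate those two changes, and whether a step of this size holds on the core of compound 1 remains open.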